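This account rests on a few compounds, and the source may have more. Where it says the series, first, only, none or still open, it means among the compounds named here.

Compound 1, `Cc1cc(C)cc(S(=O)(=O)c2c(C(=O)NCc3cccc(N)c3)[nH]c3ccc(Cl)cc23)c1`; in an ADME assay on MT4 cells (Homo sapiens) for cytotoxicity, read by MTT assay (on this read-out lower numbers stand for higher toxicity in this test and higher numbers for lower toxicity in this test), compound 1 gives > 53400 nM, a limit of the assay.
Compound 2, `Cc1cc(C)cc(S(=O)(=O)c2c(C(=O)Nc3ccnc(C#N)c3)[nH]c3ccc(Cl)cc23)c1`; compound 2 gives 6840 nM.
Compound 3, `Cc1cc(C)cc(S(=O)(=O)c2c(C(=O)NC(C)C(=O)NC(C)c3ccccc3)[nH]c3ccc(Cl)cc23)c1`; compound 3 gives 21700 nM.

Of the two numbers obtained in this assay, compound 3 stands highest. Compound 2, at 6840 nM, sits below compound 3, at 21700 nM, by a gap beyond the scatter. For compound 1 only the limit of > 53400 nM in this assay, at which 1 of the 3 values shown sits, is known, so it cannot be placed against the others in detail.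

Compound 4, `Cc1cc(C)cc(S(=O)(=O)c2c(C(=O)NC(C)c3ccccc3F)[nH]c3ccc(Cl)cc23)c1`, differs from compound 3 in one place: 2-fluorophenyl in place of (1-phenylethyl)carbamoyl on a saturated chain carbon bound to an amide-type nitrogen and a saturated chain carbon. Going by the values given here, the only measured step, an at least 7.8-fold lower number from compound 1 to compound 2 (0.89 log units; beyond the scatter), concerns a change at the amide-type nitrogen rather than at the saturated chain carbon altered here, so it does not bear directly on the present change, and no measured pair shows the effect of shortening the side chain in this way. Among the compounds with values here, with no guiding step, the account expects compound 4 to stay within the scatter of compound 3, a step of a 1.1-fold lower number from compound 3 to compound 4 (0.04 log units; within the scatter). Compound 4 is therefore estimated at 20000 nM, with a range from 6000 nM to 60000 nM.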

Compound 4, half-maximal cytotoxic concentration: > 51500 nM
Compound 4: a limit, no number; the forecaster's own chance of this, stated with the estimate: 30%; middle value at least 2.5-fold (0.41 log units) away from the limit.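

In this assay, going by these compounds alone, 2-fluorophenyl in place of (1-phenylethyl)carbamoyl on the saturated chain carbon gives an at least 2.3-fold higher number from compound 3 to compound 4 (0.37 log units; beyond the scatter), the first measured step at this place, and it shows that a change here moves the read-out beyond the scatter. As far as these compounds go, compound 4 gives a limit of the assay and not a number, so the true size of this step stays unknown: the limit of > 51500 nM in this assay, at which 1 of the 4 values shown sits. At the amide-type nitrogen, 1-(2-fluorophenyl)ethyl in place of 2-cyanopyridin-4-yl gives an at least 7.5-fold higher number from compound 2 to compound 4 (0.87 log units; beyond the scatter).

From the compounds shown here alone, the step between compound 1 and compound 4 cannot be read, as compound 1 also gives a limit of the assay: the limit of > 53400 nM in this assay, at which 1 of the 4 values shown sits. Still open is how a plain phenyl, an amine or a carboxylic acid on this saturated chain carbon would read in this assay, and so whether the fluorine or the loss of the carbamoyl carries the step.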